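Urea Aryl Replacement on the Shared Core

A few compounds are considered here, and "the series" means these few. Any claim that something is new, unique, unknown or untested is made for them only; others in the source may bear on it.

Three ureas on the shared core have been measured in an assay on CHO cells for displacement of a labelled ligand from adenosine receptor A1 (Homo sapiens), tested at 10 uM; a lower number here means less inhibition, a higher number more inhibition at the concentration tested (going by the name of the read-out). Compound 1 `O=C(Nc1ccccc1Cl)Nc1nn(-c2ccccc2)c(=O)c2ccccc12` gives 0%, compound 2 `COc1ccc(OC)c(NC(=O)Nc2nn(-c3ccccc3)c(=O)c3ccccc23)c1` gives 0%, and compound 3 `O=C(NCc1ccccc1)Nc1nn(-c2ccccc2)c(=O)c2ccccc12` gives 20%. Compound 2 therefore stands level with compound 1, the two together the lowest of the three numbers, with compound 3 the furthest away: the step of a number 20 percentage points higher from compound 2 to compound 3 (beyond the scatter) lies beyond the scatter, as does a number 20 percentage points higher from compound 1 to compound 3 (beyond the scatter). The step between the two substituted phenyl ureas, no change at the digits printed from compound 1 to compound 2 (within the scatter), lies within the scatter.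

Compound 4 `Cc1ccc(NC(=O)Nc2nn(-c3ccccc3)c(=O)c3ccccc23)cc1` arises from compound 2 by the change (4-methylphenyl in place of 2,5-dimethoxyphenyl on an amide-type nitrogen). The change keeps a six-membered aromatic ring of carbon only on the amide-type nitrogen and does not bring in the benzyl group that accompanied the rise to compound 3 in this assay. Within the data shown here, the only measured step of the same kind is the one from compound 1 to compound 2, which showed no change, and no further measurement separates one substituted phenyl from another. The expected step of a number 3 percentage points higher from compound 2 to compound 4 (within the scatter) is therefore none beyond the scatter. Compound 4 is estimated at 3%, with a range from 0% to 15%.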

Compound 4, a percentage reported as inhibition, at one concentration (the size of the read-out at that concentration, not a potency): 29%
For compound 4 the middle estimate is 26 percentage points below the measured one; the whole stated range lies below it.
By their numbers in this assay, from the lowest: compounds 1 and 2 (each within the scatter of the next); then compounds 3 and 4 (each within the scatter of the next).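

In this assay the choice of substituted phenyl on the amide-type nitrogen does matter, which the earlier pair of compounds could not show: the step of a number 29 percentage points higher from compound 2 to compound 4 (beyond the scatter) is matched by the step of a number 29 percentage points higher from compound 1 to compound 4 (beyond the scatter) and thus separates 4-methylphenyl from both 2,5-dimethoxyphenyl and 2-chlorophenyl. A benzyl group is also not required for a reading clear of these two phenyl ureas, and the step of a number 9 percentage points higher from compound 3 to compound 4 (within the scatter) gives no basis for ordering 4-methylphenyl and benzyl at this position. Nothing available bears on why 4-methylphenyl reads differently from the other two substituted phenyl groups.

Going by these compounds, what remains open is whether the methyl group itself carries the difference, a question that plain phenyl, 4-methoxyphenyl and 4-chlorophenyl on the same nitrogen would address, and how a 4-aminophenyl or 4-carboxyphenyl group would read there. Potency also remains open, as these percentages come from one concentration and do not say how compound 4 would behave across a range of concentrations.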